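A few compounds are considered here, and "the series" means these few. Any claim that something is new, unique, unknown or untested is made for them only; others in the source may bear on it.

Of the compounds shown here, two with a shared core have been measured so far in a functional assay on ASK cells (Rattus norvegicus) for cytotoxicity, read by sulforhodamine B assay (on this read-out lower numbers stand for an effect already at smaller amounts and higher numbers for an effect only at larger amounts of compound), and give different results. Compound 1 (`C=C1CC[C@@H]2[C@](C)(CO[Si](C(C)C)(C(C)C)C(C)C)[C@H](OC(C)=O)CC[C@@]2(C)[C@@H]1C/C=C1/C(=O)OC[C@H]1OC(C)=O`) gives 7.56 uM and compound 2 (`C=C1CC[C@@H]2[C@](C)(CO)[C@H](OC(C)=O)CC[C@@]2(C)[C@@H]1C/C=C1/C(=O)OC[C@H]1O`) gives 58.1 uM as the higher of the two numbers, a gap beyond the usual scatter. Compound 3 (`C=C1CC[C@@H]2[C@](C)(CO)[C@H](OC(C)=O)CC[C@@]2(C)[C@@H]1C/C=C1/C(=O)OC[C@H]1OC(C)=O`) has not yet been measured. It differs from compound 2 in one place, where acetyl in place of hydrogen on an oxygen on a saturated carbon describes the swap: acetyl in place of hydrogen on an oxygen on a saturated carbon, or hydroxy to acetoxy. Among the compounds with values here, no measured pair differs in only one place, so this expectation is tentative. A moderate move towards lower numbers is expected, beyond the scatter but not far past it. The expected change is a 2.6-fold lower number from compound 2 to compound 3 (0.42 log units; beyond the scatter) in this estimate. For compound 3 the estimated value is 22 uM with an expected range from 8 uM to 55 uM on this read-out.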

Compound 3, concentration for half-maximal effect: 11.5 uM
Estimate against measurement, compound 3: 1.9-fold (0.28 log units) above, and the stated range covers the measured number.
By their numbers in this assay, from the lowest: compounds 1 and 3 (each within the scatter of the next); then compound 2.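

In this assay, acetyl in place of hydrogen on an oxygen on a saturated carbon gives a 5.1-fold lower number from compound 2 to compound 3 (0.70 log units; beyond the scatter) and so shows, in a comparison of compounds differing in one place, that the change from hydroxy to acetoxy at this position matters. At a different oxygen on a saturated carbon, a hydrogen atom in place of a group of 10 heavy atoms (9 carbon, 1 silicon) gives a 1.5-fold higher number from compound 1 to compound 3 (0.18 log units; within the scatter) and so leaves no difference that can be told from the scatter, despite the size of that group. Nothing available explains either result.

Going by these compounds, it remains open whether the effect belongs to acetyl itself or would also appear with a methyl ether or a longer acyl chain such as butanoyl on the same oxygen. On these data alone, whether a group carrying an amine or a carboxylic acid would be tolerated there also remains unknown.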